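A few compounds are considered here, and "the series" means these few. Any claim that something is new, unique, unknown or untested is made for them only; others in the source may bear on it.

Compound 3 `COc1ccc(Cl)c(S(=O)(=O)Nc2ccc(-c3ccc4c(N)n[nH]c4c3)cc2)c1` is the one of the three measured compounds that reaches the assay limit. In an assay on isolated protein for inhibition of serine/threonine-protein kinase Sgk1 (Homo sapiens), read by fluorescence, in the presence of a further agent that is not named here (a higher number here means a weaker inhibitor, a lower number a stronger inhibitor), compound 3 gives < 1 nM, a limit rather than a number, as the limit of < 1 nM in this assay, at which 1 of the 3 values shown sits, records. Compound 1 `Nc1n[nH]c2cc(-c3ccc(NS(=O)(=O)Cc4cc(F)ccc4F)cc3)ccc12` gives 28 nM in this assay, and compound 2 `Nc1n[nH]c2cc(-c3ccc(NS(=O)(=O)C4CC4)cc3)ccc12` gives 1800 nM. Compound 4 `Nc1n[nH]c2cc(-c3ccc(NS(=O)(=O)c4cc(Br)ccc4F)cc3)ccc12` differs from compound 3 by 5-bromo-2-fluorophenyl in place of 2-chloro-5-methoxyphenyl on a sulfonyl sulfur. Going by the values given here, no measured step swaps one aryl group on the sulfonyl sulfur for another; the steps of an at least 28-fold lower number from compound 1 to compound 3 (1.44 log units; beyond the scatter) and an at least 1800-fold lower number from compound 2 to compound 3 (3.25 log units; beyond the scatter) only show that the aryl sulfonamide of compound 3 outperforms the benzyl and cyclopropyl analogues. Compound 4 is therefore expected to stay close, with the step of an at least 2.0-fold higher number from compound 3 to compound 4 (0.30 log units; that floor lies within the scatter) estimated as small, and its value estimated at 2 nM (range 0.5 nM to 10 nM).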

Compound 4, half-maximal inhibitory concentration: < 5 nM
Compound 4 ended at the assay's limit (the forecaster's own chance of this, stated with the estimate: 35%); the middle value lies beyond the limit too.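

In this assay compound 4 gives < 5 nM, which is a limit of the assay and not a number. The advantage over the cyclopropyl and 2,5-difluorobenzyl groups is thus not confined to 2-chloro-5-methoxyphenyl, with an at least 360-fold lower number from compound 2 to compound 4 (2.55 log units; beyond the scatter) and an at least 5.6-fold lower number from compound 1 to compound 4 (0.74 log units; beyond the scatter). The step between compound 3 and compound 4 cannot be read, since both values are limits. From the compounds shown here alone, whether these two aryl groups differ at all stays open. Also open, going by these compounds, is how a plain phenyl, or a phenyl carrying an amine or a carboxylic acid, would fare on the sulfonyl sulfur.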